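The source may report more compounds than this note shows. Statements on the series, on what has been measured and on what is new or still open speak of the compounds shown alone.

In a functional assay on P388 cells (Mus musculus) for antiproliferative activity, read by colorimetric assay and MTT assay (a lower number here means a stronger inhibitor, a higher number a weaker inhibitor), two compounds have been measured so far:

Compound 1 `O=S(=O)(Nc1cccc2cc[nH]c12)c1ccc(Cl)cc1`: 6 ug/mL
Compound 2 `O=[N+]([O-])c1ccc(S(=O)(=O)Nc2cccc3cc[nH]c23)cc1`: 8.2 ug/mL

Compound 2 stands highest of the two numbers, yet its nearest neighbour, compound 1, lies within the scatter of it. Among the measured compounds shown here, the only measured step, a 1.4-fold higher number from compound 1 to compound 2 (0.14 log units; within the scatter), stayed within the scatter. Compound 3 `Nc1ccc(S(=O)(=O)Nc2cccc3cc[nH]c23)cc1` differs from compound 2 by amino in place of nitro on an aromatic carbon. For the measured compounds named here, no measured step swaps nitro for amino, so the evidence is thin; the single step in this assay suggests that a change on this aromatic carbon moves the number little. For compound 3 in this assay the expected step is a 1.0-fold lower number from compound 2 to compound 3 (0.01 log units; within the scatter), nothing beyond the scatter. Compound 3 is therefore estimated at 8 ug/mL, between 3 ug/mL and 20 ug/mL.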

Compound 3, half-maximal inhibitory concentration: 14 ug/mL
Estimate against measurement, compound 3: 1.8-fold (0.24 log units) below; the range from low to high includes it.
By their numbers in this assay, from the lowest: compounds 1, 2 and 3 (each within the scatter of the next, the first and the last beyond it).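

On the aromatic carbon para to a large group, amino in place of nitro gives a 1.7-fold higher number from compound 2 to compound 3 (0.23 log units; within the scatter) in this assay, so this swap, like the earlier one, stays inside the scatter. Amino in place of chloro gives a 2.3-fold higher number from compound 1 to compound 3 (0.37 log units; beyond the scatter) and is the first step at this position to pass the scatter, though only modestly. Nothing at hand explains this step. Going by these compounds, how other groups at this position, such as methoxy or a carboxylic acid, would compare remains open. So does the effect of a methyl group elsewhere on the shared core.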